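Trimethoxyphenyl in place of chlorophenyl on the imidazolone ring

The source may hold more compounds than are shown below. What is called first, only, known or untested is meant among the compounds shown, and "the series" means these compounds.

This account follows compound 1, whose structure is `COc1cc(/C=C/C(=O)c2cccc(-n3cc(-c4ccc(Cl)cc4)[nH]c3=O)c2)cc(OC)c1OC`, as it is measured in a functional assay on ACHN cells (Homo sapiens) for inhibition; a higher number here means a weaker inhibitor of growth, a lower number a stronger inhibitor of growth. Here compound 1 gives 7170 nM, the highest number of the three values shown. Compound 2, with the structure `COc1cc(/C=C/C(=O)c2cccc(-n3cc(-c4ccccc4)[nH]c3=O)c2)ccc1O`, gives 2500 nM, and compound 3, with the structure `O=C(/C=C/c1cccc(O)c1)c1cccc(-n2cc(-c3ccc(Cl)cc3)[nH]c2=O)c1`, gives 1840 nM. Both of those compounds lie beyond the scatter of repeated measurement from compound 1, so compound 1 stands as the weakest inhibitor of growth among the three.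

Compound 4, with the structure `COc1cc(/C=C/C(=O)c2cccc(-n3cc(-c4cc(OC)c(OC)c(OC)c4)[nH]c3=O)c2)cc(OC)c1OC`, has not yet been measured in this assay. It differs from compound 1 in one place: 3,4,5-trimethoxyphenyl in place of 4-chlorophenyl on an aromatic carbon. Among the compounds with values here, no pair of measured compounds differs by this change alone, so the size of the step in this assay cannot be read off from the compounds already measured. Within the data shown here, the other two compounds keep different groups at both ends of the shared core, and their values show only that departures from compound 1 have so far given lower numbers.

Compound 4 is expected to give 5000 nM in this assay, with a range from 1500 nM to 15000 nM. The step estimated a 1.4-fold lower number from compound 1 to compound 4 (0.16 log units; within the scatter) is expected to be small, toward a somewhat lower number, and may well fall within the scatter.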

Compound 4, concentration for 50% growth inhibition: 1740 nM
Beside the measured number, compound 4's estimate is 2.9-fold (0.46 log units) above it, and the stated range covers the measured number.
By their numbers in this assay, from the lowest: compounds 4, 3 and 2 (each within the scatter of the next); then compound 1.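

Within the data shown here, the swap of 4-chlorophenyl for 3,4,5-trimethoxyphenyl in this assay gives a 4.1-fold lower number from compound 1 to compound 4 (0.61 log units; beyond the scatter), the first single change in this set whose size can be read. It shows that the group on this aromatic carbon of the five-membered aromatic ring with 2 nitrogen affects growth inhibition on its own, since the rest of compound 1 stays the same in compound 4, and that a group of 12 heavy atoms with 3 hydrogen-bond acceptors is accepted here in place of one of 7 heavy atoms with none. No measurement to hand accounts for the size or direction of this step, so the feature of the entering group that matters remains unidentified.

From the compounds shown here alone, it remains open whether a single methoxy group would give a similar step or all three are needed, and how an amine or a carboxylic acid on the phenyl ring at this position would compare. Among these compounds, it is also open whether the same swap would give a step of similar size with a different group at the other end of the shared core, such as the one carried by compound 3.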